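The source may hold more compounds than are shown below. What is called first, only, known or untested is meant among the compounds shown, and "the series" means these compounds.

Compound 1 `CC(C)=CCc1cc(C(=O)Nc2cc3ccc(OCCCNCC(C)C)c(C)c3oc2=O)ccc1O` gives 1320 nM
Compound 2 `CC(C)=CCc1cc(C(=O)Nc2cc3ccc(OCCCNC(C)C)c(C)c3oc2=O)ccc1O` gives 740 nM
Compound 3 `CC(C)=CCc1cc(C(=O)Nc2cc3ccc(OCCCN(C)C(C)(C)C)c(C)c3oc2=O)ccc1O` gives 1140 nM

All three values come from (a functional assay on MCF7 cells (Homo sapiens) for antiproliferative activity; on this read-out lower numbers stand for stronger inhibition and higher numbers for weaker inhibition). Compound 3 stands within the scatter of the other two (a 1.2-fold lower number from compound 1 to compound 3 (0.06 log units; within the scatter); a 1.5-fold higher number from compound 2 to compound 3 (0.19 log units; within the scatter)). Compound 4 (`CC(C)=CCc1cc(C(=O)Nc2cc3ccc(OCCCNCC(N)=O)c(C)c3oc2=O)ccc1O`) is the next case, with (carbamoylmethyl)amino in place of methyl(tert-butyl)amino ((carbamoylmethyl)amino in place of methyl(tert-butyl)amino on a saturated chain carbon, three bonds along the chain from an oxygen on an aromatic ring). Those two steps bear on it, as does a third (a 1.8-fold lower number from compound 1 to compound 2 (0.25 log units; within the scatter)). All three exchange groups at the same amine, and all stay within the scatter. None of them brings in a carbamoyl group, so the range is kept wide. No step beyond the scatter is expected (a 1.2-fold higher number from compound 3 to compound 4 (0.09 log units; within the scatter)). The estimate for compound 4 is (1400 nM), with an expected range from (500 nM) to (4000 nM).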

Compound 4, half-maximal inhibitory concentration: 1460 nM
The estimate for compound 4 lay 1.0-fold (0.02 log units) below the measured number; measured number inside the range.
By their numbers in this assay, from the lowest: compounds 2, 3, 1 and 4 (each within the scatter of the next).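

In this assay, (carbamoylmethyl)amino at this position, on a saturated chain carbon three bonds along the chain from an oxygen on an aromatic ring, stays within the scatter of the alkylamino groups: a 1.3-fold higher number from compound 3 to compound 4 (0.11 log units; within the scatter), a 2.0-fold higher number from compound 2 to compound 4 (0.30 log units; within the scatter) and a 1.1-fold higher number from compound 1 to compound 4 (0.04 log units; within the scatter). So the series now tolerates an amine substituent with a carbonyl and hydrogen-bond donors, not only branched alkyl groups, with no step beyond the scatter. No measurement shown accounts for this flat response. Going by these compounds, whether a carboxylic acid on this amine, or a piperidine in its place, would produce a step beyond the scatter remains open. On these data alone, a longer chain between the oxygen and the amine is equally open.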